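Swapping a Hydroxypyrrolidine for an Imidazole Ring

The source may report more compounds than this note shows. Statements on the series, on what has been measured and on what is new or still open speak of the compounds shown alone.

Measured compounds:
Compound 1 `COc1cc[nH]c1/C=C1\C(=O)Nc2ccc([N+](=O)[O-])c(N3CC[C@H](O)C3)c21` gives 104 nM.
Compound 2 `COc1cc[nH]c1/C=C1\C(=O)Nc2ccc([N+](=O)[O-])c(N3CC[C@@H](O)C3)c21` gives 88 nM.

Both numbers come from a functional assay on MDA-MB-435 cells (Homo sapiens) for antiproliferative activity, read by MTT assay, with a stated time of 5 days; on this read-out higher numbers stand for weaker inhibition and lower numbers for stronger inhibition. Among the two numbers shown, compound 2 carries the lowest one, and compound 1 is its only neighbour; the step of a 1.2-fold lower number from compound 1 to compound 2 (0.07 log units; within the scatter) goes with the fact that compounds 1 and 2 differ only in the configuration as drawn, so the two compounds are best read as equal within the scatter.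

Compound 3 `COc1cc[nH]c1/C=C1\C(=O)Nc2ccc([N+](=O)[O-])c(-n3ccnc3)c21` has not yet been measured. It differs from compound 2 in one place: 1H-imidazol-1-yl in place of 3-hydroxypyrrolidin-1-yl on an aromatic carbon. For the measured compounds named here, only one measured step exists, a 1.2-fold lower number from compound 1 to compound 2 (0.07 log units; within the scatter), and it concerns the configuration of a stereocentre inside the very group that now leaves; it says nothing about exchanging that whole group for an aromatic ring. The measured data give no direction for this change. The expectation is therefore a number near that of compound 2, with a wide range to either side, which amounts to an estimated step of a 1.5-fold higher number from compound 2 to compound 3 (0.17 log units; within the scatter) in this assay. For compound 3 the estimate in this assay is 130 nM, between 35 nM and 500 nM.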

Compound 3, half-maximal inhibitory concentration: > 30000 nM
Compound 3: only a limit was reported; the forecaster's own chance of this, stated with the estimate: 3%; at least 230-fold (2.36 log units) between middle value and limit.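

In this assay, this place on the aromatic carbon ortho to a nitro group proves far from indifferent to what sits on it, a point the two earlier compounds could not show: the exchange gives an at least 340-fold higher number from compound 2 to compound 3 (2.53 log units; beyond the scatter), and likewise an at least 280-fold higher number from compound 1 to compound 3 (2.46 log units; beyond the scatter). For compound 3, the value > 30000 nM is a limit of the assay and not a number. Taken together, the compounds show a contrast within one position: inverting the stereocentre of the 3-hydroxypyrrolidin-1-yl group leaves the numbers within the scatter, whereas replacing the whole group with 1H-imidazol-1-yl produces a large step beyond it.

The exchange alters several things at once, as a non-aromatic ring with one hetero atom and one hydrogen-bond donor gives way to an aromatic ring with two hetero atoms and no donor, so the compounds shown cannot tell which of these differences goes with the step. Also open, from the compounds shown here alone, is how a plain pyrrolidine ring without the hydroxyl group, or an open-chain amine such as dimethylamino, would behave at this position.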